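Para Chloro for Fluoro on the Phenoxy Ring

This account rests on a few compounds, and the source may have more. Where it says the series, first, only, none or still open, it means among the compounds named here.

Compound 2 `Cc1nn(C)c(Oc2ccc(F)cc2)c1/C=N\CCCCCOc1cc2oc(=O)cc(C)c2cc1Cl` was tested in a functional assay on SMMC-7721 cells (Homo sapiens) for antiproliferative activity, read by MTT assay, with a stated time of 72 h (on this read-out lower numbers stand for stronger inhibition and higher numbers for weaker inhibition), where compound 2 gives 22100 nM. Within the data shown here, its only measured neighbour, compound 1 `Cc1nn(C)c(Oc2cccc(F)c2)c1/C=N\CCCCCOc1cc2oc(=O)cc(C)c2cc1Cl`, gives 11800 nM in this assay, and the step of a 1.9-fold higher number from compound 1 to compound 2 (0.27 log units; within the scatter) separates these two positional isomers. Compound 3 `Cc1nn(C)c(Oc2ccc(Cl)cc2)c1/C=N\CCCCCOc1cc2oc(=O)cc(C)c2cc1Cl` carries the change (chloro in place of fluoro on an aromatic carbon). Among the measured compounds shown here, no measured step exchanges one halogen for another, and the only step available, between the two fluoro isomers, lies within the scatter, so no shift beyond the scatter is expected for compound 3 in this assay. Compound 3 is therefore estimated at 18000 nM, with a range of 7000 nM to 45000 nM. The expected step is a 1.2-fold lower number from compound 2 to compound 3 (0.09 log units; within the scatter).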

Compound 3, half-maximal inhibitory concentration: 17500 nM
Compound 3: middle estimate off by 1.0-fold (0.01 log units), on the high side; low and high end bracket the measured number.
By their numbers in this assay, from the lowest: compounds 1, 3 and 2 (each within the scatter of the next).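

In this assay, the exchange of one halogen for another on this aromatic carbon gives a 1.3-fold lower number from compound 2 to compound 3 (0.10 log units; within the scatter), so chloro and fluoro cannot be told apart here. Changing both the halogen and its place gives a 1.5-fold higher number from compound 1 to compound 3 (0.17 log units; within the scatter), so the three compounds remain indistinguishable in this assay. Nothing available bears on the reason for this result.

Going by these compounds, whether a methoxy group, an amine or a carboxylic acid in place of the halogen would shift the number beyond the scatter remains open. So does the effect of a shorter or longer chain.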